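Removing the ethoxy group from compound 1

This account rests on a few compounds, and the source may have more. Where it says the series, first, only, none or still open, it means among the compounds named here.

Compound 1, whose structure is `C=C(Br)C(=O)Nc1cccc(-c2cn3nc(-c4ccc(OCC)cc4)sc3n2)c1`, carries an ethoxy group on the outer benzene ring. In a functional assay on L1210 cells (Mus musculus) for inhibition, read by cell counting, with a stated time of 2 days (a higher number here means a weaker inhibitor, a lower number a stronger inhibitor), compound 1 gives 790 nM, the higher of the two numbers measured, and so the weaker of the two inhibitors. Compound 2, with the structure `C=C(Br)C(=O)Nc1cccc(-c2cn3c(-c4ccc(OC)cc4)csc3n2)c1`, has a different arrangement of the shared core and a methoxy group in place of the ethoxy; in this assay compound 2 gives 200 nM, a number beyond the usual scatter below that of compound 1. Because compound 2 differs from compound 1 in more than one place, the two values alone cannot say which change matters.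

Compound 3, with the structure `C=C(Br)C(=O)Nc1cccc(-c2cn3nc(-c4ccccc4)sc3n2)c1`, has not yet been measured in this assay. It differs from compound 1 by a single change: hydrogen in place of ethoxy on an aromatic carbon. Within the data shown here, with no measured pair showing this change on the shared core, the step from compound 1 to compound 3 is expected to be small, a modest rise in the number at most, and it may well fall within the scatter: a 1.4-fold higher number from compound 1 to compound 3 (0.14 log units; within the scatter). Compound 3 is therefore estimated at 1100 nM, with a likely range from 350 nM to 3500 nM.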

Compound 3, half-maximal inhibitory concentration: 600 nM
Estimate against measurement, compound 3: 1.8-fold (0.26 log units) above, within the range that was stated.
By their numbers in this assay, from the lowest: compound 2; then compounds 3 and 1 (each within the scatter of the next).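

In this assay, among these compounds, the swap of ethoxy for hydrogen gives a 1.3-fold lower number from compound 1 to compound 3 (0.12 log units; within the scatter), and this is the first comparison here in which only one place differs on the shared core. The 4-ethoxyphenyl and phenyl versions of this core therefore cannot be told apart in this assay, so the activity of compound 1 does not depend on having the ethoxy group at this place on the outer ring. No measurement shown here offers an explanation for this result.

As far as these compounds go, what remains open is whether other groups at this same place, such as an amine, a carboxylic acid or a longer alkoxy chain, would stay within the scatter of compound 1 or move the number beyond it. Compound 2 still differs from compound 3 in more than one place, so it also remains open whether the arrangement of the core or the methoxy group accounts for the separate position of compound 2 among these numbers.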